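Triazole substituent variation on a shared lactone core

A few compounds are considered here, and "the series" means these few. Any claim that something is new, unique, unknown or untested is made for them only; others in the source may bear on it.

Measured compounds:
compound 1 `O=C1O[C@H]([C@@H](O)Cn2cc(-c3ccc(Br)cc3)nn2)C(OCc2ccccc2)=C1OCc1ccccc1` — 5070 nM
compound 2 `CC(C)(C)c1cn(C[C@H](O)[C@H]2OC(=O)C(OCc3ccccc3)=C2OCc2ccccc2)nn1` — 29200 nM
compound 3 `Cc1ccc(S(=O)(=O)NCc2cn(C[C@H](O)[C@H]3OC(=O)C(OCc4ccccc4)=C3OCc3ccccc3)nn2)cc1` — 24900 nM

In a functional assay on HepG2 cells (Homo sapiens) for antiproliferative activity, read by MTT assay, with a stated time of 72 h (a higher number here means a weaker inhibitor, a lower number a stronger inhibitor), compound 1 gives 5070 nM, compound 2 gives 29200 nM and compound 3 gives 24900 nM. Compound 3 therefore stands second highest of the three numbers; its nearest neighbour is compound 2, and the pair differ only within the scatter (a 1.2-fold lower number from compound 2 to compound 3 (0.07 log units; within the scatter)), while compound 1 lies well below it (a 4.9-fold higher number from compound 1 to compound 3 (0.69 log units; beyond the scatter)).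

Compound 4 `COc1ccc(-c2cn(C[C@H](O)[C@H]3OC(=O)C(OCc4ccccc4)=C3OCc3ccccc3)nn2)cc1` differs from compound 3 in one place: 4-methoxyphenyl in place of (((4-methylphenyl)sulfonyl)amino)methyl on an aromatic carbon. Among the compounds with values here, the steps that bear on this change are those in which the group on the same aromatic carbon was varied: a 5.8-fold higher number from compound 1 to compound 2 (0.76 log units; beyond the scatter) and a 4.9-fold higher number from compound 1 to compound 3 (0.69 log units; beyond the scatter). Both show that an aryl group at this position, as in compound 1, goes with a clearly lower number than either the tert-butyl or the sulfonamide-bearing chain. Compound 4 carries an aryl group again, so the step of a 3.6-fold lower number from compound 3 to compound 4 (0.55 log units; beyond the scatter) is expected, a modest move downward of about the size seen between compound 1 and compound 3.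

For compound 4 in this assay the estimate is 7000 nM, with a range from 2500 nM to 20000 nM.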

Compound 4, half-maximal inhibitory concentration: 46400 nM
Beside the measured number, compound 4's estimate is 6.6-fold (0.82 log units) below it, and the stated range ends below it.
By their numbers in this assay, from the lowest: compound 1; then compounds 3, 2 and 4 (each within the scatter of the next).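

In this assay, an aryl group on this aromatic carbon does not by itself go with the lowest number: with methoxy in place of bromo, the series shows a 9.2-fold higher number from compound 1 to compound 4 (0.96 log units; beyond the scatter). Compound 4 instead falls in with the non-aryl compounds, with a 1.9-fold higher number from compound 3 to compound 4 (0.27 log units; within the scatter) and a 1.6-fold higher number from compound 2 to compound 4 (0.20 log units; within the scatter), so 4-methoxyphenyl, tert-butyl and (((4-methylphenyl)sulfonyl)amino)methyl cannot be told apart here, and among the compounds shown only the 4-bromophenyl of compound 1 stands apart. No supporting data explain the separation of compound 1 from compound 4.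

Within the data shown here, with only two aryl compounds, it remains open whether the separation is specific to bromo or would also appear with chloro or an unsubstituted phenyl. An amine or a carboxylic acid in that same place on the aryl ring also remains to be placed against these values.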